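The source may report more compounds than this note shows. Statements on the series, on what has been measured and on what is new or still open speak of the compounds shown alone.

Of the compounds shown here, two have numbers so far in a functional assay on P388 cells (Mus musculus) for antiproliferative activity, read by colorimetric assay and MTT assay; a lower number here means a stronger inhibitor, a higher number a weaker inhibitor. Compound 1 (`Nc1ccc(S(=O)(=O)Nc2cccc3cc(O)[nH]c23)cc1`) gives 1.2 ug/mL, and compound 2 (`Nc1ccc(S(=O)(=O)Nc2ccc(F)c3c(Cl)c[nH]c23)cc1`) gives 0.51 ug/mL, the lower of the two numbers, with a gap beyond the usual scatter. Compound 3 (`COc1ccc(NS(=O)(=O)c2ccc(N)cc2)c2[nH]cc(Cl)c12`) keeps the core of compound 2 and changes one substituent: methoxy in place of fluoro on an aromatic carbon, para to a large group. Going by the values given here, no measured pair isolates a change at this place, and compound 1 and compound 2 differ in more than one place, so their gap gives no direct guide to this swap. A step within the scatter is expected, with a slight lean toward a higher number. The estimated step is a 1.4-fold higher number from compound 2 to compound 3 (0.14 log units; within the scatter). In this assay the expected value for compound 3 is 0.7 ug/mL, with an estimated range of 0.25 ug/mL to 2 ug/mL.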

Compound 3, half-maximal inhibitory concentration: 5.5 ug/mL
The estimate for compound 3 lay 7.9-fold (0.90 log units) below the measured number; measured number above the stated range.
By their numbers in this assay, from the lowest: compound 2; then compound 1; then compound 3.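

In this assay, going by these compounds alone, methoxy in place of fluoro on this aromatic carbon, para to a large group, gives an 11-fold higher number from compound 2 to compound 3 (1.03 log units; beyond the scatter), the first change isolated at a single place. The position is therefore sensitive to the substituent it carries, and of the two groups compared here, fluoro goes with the lower number and so the stronger inhibition. No measured data bear on the reason for this step.

This single swap changes the heavy atoms and the hydrogen-bond acceptor count together, so it cannot show which of the two differences matters, if either. As far as these compounds go, whether chain-only methyl, ethoxy, an amine or a nitrile on this carbon would stay close to compound 2 or move toward compound 3 remains open.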